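A Methoxy-to-Trifluoromethyl Swap on a Shared Core

The compounds below may be only part of what the source reports. "The series", "measured", "known", "first", "only" and "open" are said of these compounds alone.

Compound 1, `COc1ccc(-c2nc(-c3ccccc3)c(-c3ccc4c(c3)NC(=O)CO4)[nH]2)cc1`, was examined in a functional assay on A549 cells (Homo sapiens) for cytotoxicity, read by colorimetric assay and MTT assay, with a stated time of 3 days, tested at 1 uM (a lower number here means a stronger effect, a higher number a weaker effect of the compound at the concentration tested), where compound 1 gives 101%. That is the higher of the two numbers recorded so far, meaning the weaker effect. The second measured compound, compound 2 with structure `O=C1COc2ccc(-c3nn(-c4ccc(F)cc4)cc3-c3ccccc3)cc2N1`, gives in this assay 78.2%, a number that lies beyond the usual scatter below that of compound 1. The two share no single-point difference, so their values are only placed side by side here.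

Compound 3, `O=C1COc2ccc(-c3[nH]c(-c4ccc(C(F)(F)F)cc4)nc3-c3ccccc3)cc2N1`, has not yet been measured. It departs from compound 1 by trifluoromethyl in place of methoxy on an aromatic carbon. Among the measured compounds shown here, with no measured step of this kind available, the expectation rests on compound 1 alone: the step of a number 9 percentage points lower from compound 1 to compound 3 (within the scatter) is expected to be small, likely toward a slightly lower number, though a step within the scatter would not surprise. Compound 3 is therefore estimated at 92% in this assay, within a range from 68% to 106%.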

Compound 3, a percentage reported as activity, at one concentration (the size of the read-out at that concentration, not a potency): 103%
Estimate against measurement, compound 3: 11 percentage points below, and the stated range covers the measured number.
By their numbers in this assay, from the lowest: compound 2; then compounds 1 and 3 (each within the scatter of the next).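

In this assay, trifluoromethyl in place of methoxy gives a number 2 percentage points higher from compound 1 to compound 3 (within the scatter), the first single-point comparison available on the shared core. At this position, para to a large group, the 4-methoxyphenyl and 4-(trifluoromethyl)phenyl versions therefore cannot be told apart at the one concentration tested, even though the two groups differ in heavy atoms and only methoxy counts a hydrogen-bond acceptor. Nothing measured here gives a reason for this outcome.

Going by these compounds, whether an amine, a carboxylic acid or a longer chain at this same place would also stay within the scatter of compound 1 remains open. The compounds shown also leave open whether this swap would give a similarly small step at another concentration or on a different core.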